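Furan-2-yl in Place of Phenyl: Outlook for Compound 3

The source may hold more compounds than are shown below. What is called first, only, known or untested is meant among the compounds shown, and "the series" means these compounds.

Compound 1: `O=C(O)Cc1sc(C(c2ccc(F)cc2)c2ccc(F)cc2)nc1-c1ccccc1` — 16 nM
Compound 2: `O=C(O)Cc1sc(C(c2ccccc2)c2ccccc2)nc1-c1ccc(F)cc1` — 8.7 nM

Among the compounds with values here, in an in vitro assay on HEK385-7 cells for displacement of a labelled ligand from prostaglandin D2 receptor 2 (Homo sapiens) (a lower number here means a stronger inhibitor, a higher number a weaker inhibitor), compound 1 gives 16 nM, the higher of the two numbers measured so far. Compound 2 gives 8.7 nM, a value that lies within the usual scatter of that of compound 1, so the two cannot be told apart on these data. Compound 3 `O=C(O)Cc1sc(C(c2ccc(F)cc2)c2ccc(F)cc2)nc1-c1ccco1` keeps everything of compound 1 except one group: furan-2-yl in place of phenyl on an aromatic carbon. Within the data shown here, no pair among the measured compounds shows this kind of exchange, so nothing here tells how large a step it brings. A modest move toward a higher number, or none beyond the scatter, is the expectation. Compound 3 is therefore expected to give 25 nM, with a plausible range from 8 nM to 80 nM. The expected step of a 1.6-fold higher number from compound 1 to compound 3 (0.19 log units; within the scatter) is small and should not stand clearly beyond the scatter.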

Compound 3, half-maximal inhibitory concentration: 18 nM
Estimate against measurement, compound 3: 1.4-fold (0.14 log units) above, within the range that was stated.
By their numbers in this assay, from the lowest: compounds 2, 1 and 3 (each within the scatter of the next, the first and the last beyond it).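

In this assay, furan-2-yl in place of phenyl on the aromatic carbon next to the ring nitrogen gives a 1.1-fold higher number from compound 1 to compound 3 (0.05 log units; within the scatter). Within the data shown here, this position therefore accepts a five-membered aromatic ring with 1 hetero atom in place of a six-membered aromatic ring of carbon only, with no step that can be told from the scatter. The hydrogen-bond acceptor that furan-2-yl brings, and phenyl lacks, likewise leaves the number within the scatter. Nothing on hand gives a reason for this result.

The compounds shown leave open whether a ring that is not aromatic, such as cyclohexyl, or a much smaller group, such as methyl, would hold the number at this position. They also leave open whether a ring nitrogen, as in pyridin-2-yl, would be accepted here as furan-2-yl is.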